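The compounds below may be only part of what the source reports. "The series", "measured", "known", "first", "only" and "open" are said of these compounds alone.

Series notes. Compound 1 `CCC1(Cc2ccccc2)OS(=O)(=O)C=C1OCc1ccc(F)cc1` carries a 4-fluorobenzyl group on the shared core. In an ADME assay on HEL cells (Homo sapiens) for cytotoxicity, with a stated time of 3 days (a higher number here means that more compound is tolerated, a lower number that less compound is tolerated), compound 1 gives only a limit, >= 50000 nM; this is the limit of >= 50000 nM in this assay, at which 1 of the 3 values shown sits, and not a measured number. Compound 2 `CCC1(Cc2ccccc2)OS(=O)(=O)CC1=O` also reaches only a limit in this assay, > 100000 nM, which is the limit of > 100000 nM in this assay, at which 1 of the 3 values shown sits. Compound 3 `CC(C)CC1(Cc2ccccc2)OS(=O)(=O)C=C1OCc1ccccc1` likewise stops at a limit in this assay, >= 80000 nM, corresponding to the limit of >= 80000 nM in this assay, at which 1 of the 3 values shown sits. All three values therefore sit at the edge of what was tested, and no order among the three compounds can be read from them. Among the measured compounds shown here, no step between two measured compounds is available in this assay, so no change has yet been seen. Compound 4 `CCC1(Cc2ccccc2)OS(=O)(=O)C=C1OCc1ccc(Cl)cc1` differs from compound 1 by chloro in place of fluoro on an aromatic carbon. The step from compound 1 to compound 4 in this assay is expected to be small, within the usual scatter, or absent, with the result again most probably a limit. Compound 4 is estimated at 60000 nM in this assay, with a range from 20000 nM to 150000 nM. The step this estimate implies is a step that the limit leaves unreadable from compound 1 to compound 4.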

Compound 4, minimum cytotoxic concentration: >= 50000 nM
Compound 4 gave a limit, no number; the forecaster's own chance of this, stated with the estimate: 80%; the middle value lies beyond the limit too.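

In this assay no step can be read from compound 1 to compound 4, as both stop at the same limit: the limit of >= 50000 nM in this assay, at which 2 of the 4 values shown sit.

The compounds shown leave open how far the tolerated concentration of either lies past that limit, and so whether chloro and fluoro differ at all in this read-out.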